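Cytotoxicity notes on a benzylimidazole aniline series

This account rests on a few compounds, and the source may have more. Where it says the series, first, only, none or still open, it means among the compounds named here.

Measured so far:
compound 1, `COC(=O)c1ccc(NCc2cncn2Cc2cccc(F)c2)cc1-c1ccccc1` — > 1000 nM
compound 2, `COC(=O)c1ccc(NCc2cncn2Cc2ccccc2F)cc1-c1ccccc1` — "not determined" (no result reported)

In a toxicity assay on NIH3T3 cells (Mus musculus) for cytotoxicity, read by resazurin assay (a higher number here means that more compound is needed for the effect, a lower number that less compound is needed), compound 1 reaches only a limit of the assay, > 1000 nM. For compound 2 the result in this assay is "not determined" (no result reported), so compound 2 stands without a number; of the two values shown, (the limit of > 1000 nM in this assay, at which 1 of the 2 values shown sits).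

Compound 3, `COC(=O)c1ccc(NCc2cncn2Cc2cccc(Cl)c2)cc1-c1ccccc1`, differs from compound 2 by 3-chlorophenyl in place of 2-fluorophenyl on a saturated chain carbon bound to an aromatic nitrogen. Among the measured compounds shown here, with no number for compound 2, no step in this assay can be sized; compound 3 is expected to sit where compound 1 does, at the limit. The estimate for compound 3 is 3000 nM, within 1000 nM to 10000 nM.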

Compound 3, half-maximal effective concentration: > 10000 nM
Compound 3: only a limit was reported (the forecaster's own chance of this, stated with the estimate: 80%); middle value at least 3.3-fold (0.52 log units) from the limit.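

Among the compounds shown here, no step in this assay can be read among compound 1, compound 2 and compound 3, as compound 1 and compound 3 give only limits. Open remains where their half-maximal concentrations lie, and whether chloro in place of fluoro shifts them.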